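This account rests on a few compounds, and the source may have more. Where it says the series, first, only, none or still open, it means among the compounds named here.

Compound 1, `COc1ccc(CC[C@@H](OC(=O)[C@@H]2CCCCN2C(=O)c2nccc3ccccc23)c2cccc(OCC(=O)O)c2)cc1OC`, is the starting point of this account. In a physicochemical assay for solubility (a lower number here means a less soluble compound, a higher number a more soluble compound), compound 1 gives a limit rather than a number, > 10000 nM. Compound 2, `COc1ccc(CC[C@@H](OC(=O)[C@@H]2CCCCN2C(=O)c2cccc3cccnc23)c2cccc(OCC(=O)O)c2)cc1OC`, is also reported in this assay only as a limit, > 10000 nM. Compound 3, `COc1ccc(CC[C@@H](OC(=O)[C@@H]2CCCCN2C(=O)[C@@H]2CCCc3ccccc32)c2cccc(OCC(=O)O)c2)cc1OC`, reaches a limit in this assay as well, > 10000 nM. The steps a step that the two limits leave unreadable from compound 1 to compound 2, a step that the two limits leave unreadable from compound 1 to compound 3 and a step that the two limits leave unreadable from compound 2 to compound 3 therefore have no readable size, because the limit of > 10000 nM in this assay, at which 3 of the 3 values shown sit, is where every value shown stands.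

Compound 4, `COc1ccc(CC[C@@H](OC(=O)[C@@H]2CCCCN2C(=O)C2=CCc3ccccc32)c2cccc(OCC(=O)O)c2)cc1OC`, has not yet been measured. Its change from compound 1 is a group of 9 heavy atoms (9 carbon; one five-membered non-aromatic ring of carbon only, one six-membered aromatic ring of carbon only) in place of a group of 10 heavy atoms (9 carbon, 1 nitrogen; one six-membered aromatic ring of carbon only, one six-membered aromatic ring with 1 hetero atom), on a carbonyl carbon. The measured steps that bear on it are the three exchanges on the same carbonyl carbon, above all a step that the two limits leave unreadable from compound 1 to compound 2 and a step that the two limits leave unreadable from compound 1 to compound 3, since each of them also removes the isoquinolin-1-yl group; none of them yields a direction or a size, so no step beyond the scatter, in either direction, can be derived from them. Compound 4 is therefore expected to remain at the same limit, with the estimate 15000 nM ranging from 7000 nM to 40000 nM. The step that the limit leaves unreadable from compound 1 to compound 4 is likewise expected to be unreadable, held at the limit.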

Compound 4, solubility: > 10000 nM
Compound 4: only a limit was reported (the forecaster's own chance of this, stated with the estimate: 80%); the middle value is on the limit's open side.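

In this assay compound 4 gives the limit > 10000 nM and no number. Its steps to compound 1, compound 2 and compound 3 cannot be read, because all four compounds stand at the same limit: the limit of > 10000 nM in this assay, at which 4 of the 4 values shown sit. The compounds shown leave open how far past that limit each one lies, and whether exchanging the group on the carbonyl carbon changes the read-out at all.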